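The source may report more compounds than this note shows. Statements on the series, on what has been measured and on what is new or still open speak of the compounds shown alone.

Of the compounds shown here, three with a shared core have been measured in an assay on isolated protein for inhibition of Amine oxidase [flavin-containing] A (Homo sapiens), read by fluorescence, with stated times of 15 min and 20 min; on this read-out lower numbers stand for stronger inhibition and higher numbers for weaker inhibition. Compound 1 `CC(C)(C)c1cc(CCC(=O)NC2CCN(Cc3ccccc3)CC2)cc(C(C)(C)C)c1O` gives 90200 nM. Compound 2 `CC(C)(C)c1cc(CCC(=O)NCCC2CCN(Cc3ccccc3)CC2)cc(C(C)(C)C)c1O` gives 94100 nM. Compound 3 `Cc1ccc(CN2CCC(CCNC(=O)/C=C/c3cc(C(C)(C)C)c(O)c(C(C)(C)C)c3)CC2)cc1` gives 70100 nM, the lowest of the three numbers, yet it sits within the scatter of both compound 1 and compound 2, so no order among the three can be read from these values.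

Compound 4 `CC(C)(C)c1cc(/C=C/C(=O)NCCC2CCN(Cc3cccc(Cl)c3)CC2)cc(C(C)(C)C)c1O` has not yet been measured in this assay. It differs from compound 3 in one place: 3-chlorophenyl in place of 4-methylphenyl on a saturated chain carbon bound to an amine nitrogen in a ring. Going by the values given here, no measured pair shows this kind of change, so nothing on record says which way it should move the number.

Compound 4 is therefore expected to give a value close to that of compound 3, with a step of a 1.0-fold lower number from compound 3 to compound 4 (0.00 log units; within the scatter) that need not exceed the scatter. The estimate for compound 4 is 70000 nM, within a range from 30000 nM to 160000 nM.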

Compound 4, half-maximal inhibitory concentration: 65100 nM
The estimate for compound 4 lay 1.1-fold (0.03 log units) above the measured number; low and high end bracket the measured number.
By their numbers in this assay, from the lowest: compounds 4, 3, 1 and 2 (each within the scatter of the next).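

Going by these compounds alone, compounds 3 and 4 are the first pair here that differ in only one place, on a saturated chain carbon bound to an amine nitrogen in a ring. In this assay, 3-chlorophenyl in place of 4-methylphenyl gives a 1.1-fold lower number from compound 3 to compound 4 (0.03 log units; within the scatter), so this swap of one substituted phenyl for another leaves the number within the scatter. It does not show which of the two groups is better, or what either substituent does alone.

Still open, going by these compounds, is whether a carboxylic acid or an amine on that phenyl ring, or a longer chain to it, would move the number beyond the scatter. Nothing on record accounts for this result.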